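The source may hold more compounds than are shown below. What is called first, only, known or untested is meant among the compounds shown, and "the series" means these compounds.

Measured compounds:
- compound 1 `CCCc1cc(=O)n([C@@H]2O[C@H](COP(=O)(O)OP(=O)(O)OP(=O)(O)O)[C@@H](O)[C@H]2O)c(=O)[nH]1`; in an in vitro functional assay on 1321-N1 cells for agonist activity at P2Y purinoceptor 6 (Homo sapiens) (a lower number here means that less compound is needed, a higher number that more compound is needed for the effect), compound 1 gives > 100000 nM, a limit of the assay.
- compound 2 `CCCc1cc(=O)n([C@@H]2O[C@H](COP(=O)(O)OP(=O)(O)O)[C@@H](O)[C@H]2O)c(=O)[nH]1`; in this assay compound 2 gives > 1000 nM, again a limit.
- compound 3 `Cc1cc(=O)n([C@@H]2O[C@H](COP(=O)(O)O)[C@@H](O)[C@H]2O)c(=O)[nH]1`; in this assay compound 3 gives > 100000 nM, a limit.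

Compound 3 therefore stands at a limit, not at a number: the limit of > 100000 nM in this assay, at which 2 of the 3 values shown sit, while (the limit of > 1000 nM in this assay, at which 1 of the 3 values shown sits). For the measured compounds named here, the one step that joins two measured compounds in a single place, a step that the two limits leave unreadable from compound 1 to compound 2, concerns the phosphate chain and cannot be read in size. The change to compound 4 `CCCc1cc(=O)n([C@@H]2O[C@H](COP(=O)(O)O)[C@@H](O)[C@H]2O)c(=O)[nH]1` is ethyl in place of hydrogen on a saturated chain carbon bound to an aromatic carbon. Going by the values given here, no measured pair differs in that place alone; compound 1 and compound 2 carry the propyl but sit on other phosphate chains than compound 3, so their values give no reading of the alkyl step. Among the compounds with values here, the expectation for compound 4 is therefore only that it stays where compound 3 stands, with the step that the limit leaves unreadable from compound 3 to compound 4 expected to show nothing readable. Compound 4 is estimated at 200000 nM, within 30000 nM to 1000000 nM, most likely reported as a limit.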

Compound 4, half-maximal effective concentration: > 100000 nM
Compound 4: a limit, no number; the forecaster's own chance of this, stated with the estimate: 85%; the middle value does not contradict the limit.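

In this assay compound 4 gives > 100000 nM, a limit of the assay. The steps to compound 4 from compound 1, compound 2 and compound 3 cannot be read in size. The compounds shown leave open what either the alkyl chain or the phosphate chain does to the half-maximal effective concentration, as none of them gives a number.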